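Swapping the indazolyl arm for trifluoromethylphenyl

The source may report more compounds than this note shows. Statements on the series, on what has been measured and on what is new or still open speak of the compounds shown alone.

In a functional assay on B16-F0 cells (Mus musculus) for inhibition, read by CCK-8 assay, with a stated time of 48 h (a lower number here means a stronger inhibitor, a higher number a weaker inhibitor), compound 1 `COc1cc(-c2ccnc3cc(-c4ccc(C)cc4)nn23)cc(OC)c1OC` gives 21 nM and compound 3 `COc1cc(-c2ccnc3cc(-c4ccc5cnn(C)c5c4)nn23)cc(OC)c1OC` gives 1000 nM. For compound 2 `COc1cc(-c2ccnc3cc(-c4ccc(C(C)(C)C)cc4)nn23)cc(OC)c1OC` this assay reports only a limit, > 10000 nM (the limit of > 10000 nM in this assay, at which 1 of the 3 values shown sits). Of the two numbers, compound 3 stands highest, separated from compound 1 by a 48-fold higher number from compound 1 to compound 3 (1.68 log units; beyond the scatter). Compound 4 `COc1cc(-c2ccnc3cc(-c4ccc(C(F)(F)F)cc4)nn23)cc(OC)c1OC` is not yet measured; (4-(trifluoromethyl)phenyl in place of 1-methyl-1H-indazol-6-yl on an aromatic carbon). Going by the values given here, two measured steps bear on it: an at least 470-fold higher number from compound 1 to compound 2 (2.67 log units; beyond the scatter), tert-butyl in place of methyl, and an at least 10-fold lower number from compound 2 to compound 3 (1.00 log units; beyond the scatter). Compound 4 carries trifluoromethyl in place of the methyl of compound 1 or the tert-butyl of compound 2, so its number is expected to fall between those two, with a step of a 3.3-fold lower number from compound 3 to compound 4 (0.52 log units; beyond the scatter) expected. The estimate for compound 4 is 300 nM, expected within 40 nM to 3000 nM.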

Compound 4, half-maximal inhibitory concentration: 1770 nM
The estimate for compound 4 lay 5.9-fold (0.77 log units) below the measured number, within the range that was stated.
By their numbers in this assay, from the lowest: compound 1; then compounds 3 and 4 (each within the scatter of the next). At a limit, above all of these: compound 2.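

In this assay, trifluoromethyl in place of methyl is a large loss, with an 84-fold higher number from compound 1 to compound 4 (1.93 log units; beyond the scatter), whereas trifluoromethyl in place of tert-butyl regains only part of the ground, with an at least 5.6-fold lower number from compound 2 to compound 4 (0.75 log units; beyond the scatter). Compound 2 stands at a limit: the limit of > 10000 nM in this assay, at which 1 of the 4 values shown sits.

The 4-(trifluoromethyl)phenyl and 1-methyl-1H-indazol-6-yl arms are not separated in this series, with a 1.8-fold higher number from compound 3 to compound 4 (0.25 log units; within the scatter).

Among the compounds shown, only the methyl of compound 1 gives a low number, so it remains open whether chloro, methoxy or an amine on the same phenyl arm would keep it.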